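Cytotoxicity notes on a dipyridyl series: methoxy to chloro

The source may report more compounds than this note shows. Statements on the series, on what has been measured and on what is new or still open speak of the compounds shown alone.

Measured so far:
- compound 1, `COC(=O)C1=C(O)C[C@H](c2ccccn2)N(Cc2ccc(OC)cc2)[C@@H]1c1ccccn1`: 29.9 uM in an ADME assay on J774.1 cells (Mus musculus) for cytotoxicity, with a stated time of 48 h; a higher number here means that more compound is needed for the effect, a lower number that less compound is needed
- compound 2, `Clc1cccc(Cl)c1CO/N=C/C1CCN(CCCc2ccccc2)CC1`: 28.4 uM

Two compounds have been run in this assay, and they share no common change that could be read as a step. Compound 1 gives 29.9 uM and compound 2 gives 28.4 uM; the two numbers lie within the scatter of each other, so no order between them is claimed. Compound 1 carries the higher of the two numbers by a margin that means nothing.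

The next compound is compound 3, `COC(=O)C1=C(O)C[C@H](c2ccccn2)N(Cc2ccc(Cl)cc2)[C@@H]1c1ccccn1`, not yet measured in this assay. Against compound 1 the change is chloro in place of methoxy on an aromatic carbon. Nothing measured here speaks to the effect of chloro in place of methoxy on an aromatic carbon, so the step is set by the usual behaviour of such a swap in a cell-based toxicity read-out, which is small. The step from compound 1 to compound 3 is expected to be a 1.2-fold lower number from compound 1 to compound 3 (0.10 log units; within the scatter), within the scatter or at most slightly below it. Compound 3 is therefore estimated at 24 uM, with a range from 11 uM to 52 uM.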

Compound 3, concentration for half-maximal effect: 32.8 uM
For compound 3 the middle estimate is 1.4-fold (0.14 log units) below the measured one; measured number inside the range.
By their numbers in this assay, from the lowest: compounds 2, 1 and 3 (each within the scatter of the next).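

With the step of a 1.1-fold higher number from compound 1 to compound 3 (0.04 log units; within the scatter) in this assay, replacing methoxy with chloro on an aromatic carbon of a six-membered aromatic ring of carbon only, para to a large group, produces no change that this read-out can separate from scatter. This is the only pair shown that differs in one place, so it gives the position its sole reading so far: the 4-methoxybenzyl and 4-chlorobenzyl forms of the shared core cannot be told apart here, even though the methoxy brings an extra heavy atom and a hydrogen-bond acceptor that the chloro lacks. Nothing available bears on why the two compounds read alike.

A single swap between two neutral groups leaves open whether the position stays this flat for a group of another kind, such as an amine, a carboxylic acid or a longer chain in the same place. It also leaves open whether the same swap would read alike on another core, or at another site on this aromatic ring.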